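Hydrogen in Place of Hydroxy on Compound 2

This account rests on a few compounds, and the source may have more. Where it says the series, first, only, none or still open, it means among the compounds named here.

Of the compounds shown here, two built on one shared core have been measured so far. In a functional assay on HepG2 cells (Homo sapiens) for inhibition, read by MTT assay, with a stated time of 24 h (on this read-out higher numbers stand for weaker inhibition and lower numbers for stronger inhibition), compound 1 `CC1(C)[C@H]2CC[C@]1(C)N(Cc1cn(-c3ccccc3Cl)nn1)C(=O)C2` gives 60 nM, and compound 2 `CC1(C)[C@H]2CC[C@]1(C)N(Cc1cn(-c3ccc(O)cc3)nn1)C(=O)C2` gives 80 nM. Among the measured compounds shown here, these two values lie within the usual scatter of each other, so the numbers do not separate compound 2 from the only other compound measured.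

The next compound, compound 3 `CC1(C)[C@H]2CC[C@]1(C)N(Cc1cn(-c3ccccc3)nn1)C(=O)C2`, has hydrogen in place of hydroxy on an aromatic carbon, so 4-hydroxyphenyl becomes phenyl: hydrogen in place of hydroxy on an aromatic carbon. For the measured compounds named here, only one measured step offers any guidance, and it is a 1.3-fold higher number from compound 1 to compound 2 (0.12 log units; within the scatter). That step exchanged one substituted phenyl group for another and stayed within the scatter. Going by the values given here, it is limited evidence, as no measured compound carries the plain phenyl group and the hydroxy group has not been changed on its own. Even so, no shift beyond the scatter is expected in this assay. The expected change is a 1.1-fold lower number from compound 2 to compound 3 (0.06 log units; within the scatter), which is too small to give a direction. For compound 3 the estimated value is 70 nM, with an expected range from 25 nM to 200 nM.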

Compound 3, half-maximal inhibitory concentration: 90 nM
The estimate for compound 3 lay 1.3-fold (0.11 log units) below the measured number; low and high end bracket the measured number.
By their numbers in this assay, from the lowest: compounds 1, 2 and 3 (each within the scatter of the next).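

In this assay, among the compounds shown here, hydrogen in place of hydroxy gives a 1.1-fold higher number from compound 2 to compound 3 (0.05 log units; within the scatter), and this is the first step that changes the hydroxy group on its own, so it shows that taking this group off the aromatic carbon leaves the number within the scatter. Compound 3 also gives a plain phenyl reference for the chloro group of compound 1: hydrogen in place of chloro gives a 1.5-fold higher number from compound 1 to compound 3 (0.18 log units; within the scatter), so neither the 2-chlorophenyl nor the 4-hydroxyphenyl compound can be told apart from the phenyl compound in this assay, and within these three compounds the substituent makes no readable difference. No measurement is available here that could explain why these numbers lie so close together.

Whether an amine or a carboxylic acid on this same aromatic carbon would move the number beyond the scatter remains open, since hydroxy and hydrogen are the only groups shown there. Also open, from the compounds shown here alone, is whether the phenyl ring itself matters, which a compound carrying a plain alkyl chain on the triazole nitrogen in its place could test.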